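Aryl urea series: dimethoxyphenyl in place of trimethylphenyl

The source may hold more compounds than are shown below. What is called first, only, known or untested is meant among the compounds shown, and "the series" means these compounds.

Measured in an assay on microsomes from intestinal mucosa for inhibition of acyl-CoA:cholesterol acyltransferase (Oryctolagus cuniculus); on this read-out higher numbers stand for weaker inhibition and lower numbers for stronger inhibition:
compound 1 `CCCCCCCC/C=C\CCCCCCCCNC(=O)Nc1c(C)cccc1C`: 160 nM
compound 2 `CCCCCCCC/C=C\CCCCCCCCNC(=O)Nc1c(C)cc(C)cc1C`: 2900 nM

Among the measured compounds shown here, compound 2 gives the highest of the two numbers; the step from it to its only neighbour is an 18-fold higher number from compound 1 to compound 2 (1.26 log units; beyond the scatter), a methyl in place of hydrogen on an aromatic carbon. Compound 3 `CCCCCCCC/C=C\CCCCCCCCNC(=O)Nc1ccc(OC)cc1OC` differs from compound 2 by 2,4-dimethoxyphenyl in place of 2,4,6-trimethylphenyl on an amide-type nitrogen. For the measured compounds named here, no measured step covers this exchange; the one step seen only shows that the third methyl costs much. Since compound 3 carries only two substituents, the number is expected to move back toward compound 1, a step of a 7.3-fold lower number from compound 2 to compound 3 (0.86 log units; beyond the scatter) in this assay. Compound 3 is therefore estimated at 400 nM, between 100 nM and 2000 nM.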

Compound 3, half-maximal inhibitory concentration: 5400 nM
Estimate against measurement, compound 3: 14-fold (1.13 log units) below; measured number above the stated range.
By their numbers in this assay, from the lowest: compound 1; then compounds 2 and 3 (each within the scatter of the next).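

In this assay, 2,4-dimethoxyphenyl on the amide-type nitrogen gives a 1.9-fold higher number from compound 2 to compound 3 (0.27 log units; within the scatter) and so cannot be told apart from 2,4,6-trimethylphenyl. Carrying only two ring substituents therefore does not by itself restore the level of compound 1: the exchange for 2,6-dimethylphenyl gives a 34-fold higher number from compound 1 to compound 3 (1.53 log units; beyond the scatter) on the same read-out. No measurement at hand offers an explanation for this result.

Open, going by these compounds, is whether a plain phenyl or a 4-chlorophenyl on this nitrogen would read near compound 1 or near compound 2 and compound 3. Also open, on these data alone, is whether the number of ring substituents or their kind governs the read-out.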